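The compounds below may be only part of what the source reports. "The series", "measured", "known", "first", "only" and "open" are said of these compounds alone.

Working notes on the series. Compound 1 `COc1ccc(N2C(=O)COc3ccc(-c4cnc(Cl)c(NS(=O)(=O)c5ccc(F)cc5)c4)cc32)cc1` is the one numerical anchor in a functional assay on A-375 cells (Homo sapiens) for antiproliferative activity, read by MTT assay, with a stated time of 72 h; a higher number here means a weaker inhibitor, a lower number a stronger inhibitor; in that assay compound 1 gives 32700 nM. Compound 2 `O=C1COc2ccc(-c3cnc(Cl)c(NS(=O)(=O)c4ccc(F)cc4)c3)cc2N1c1ccc(F)cc1` keeps the same core. In this assay compound 2 reaches only a limit of the assay, > 40000 nM. The change between them is fluoro in place of methoxy on an aromatic carbon, and the step is an at least 1.2-fold higher number from compound 1 to compound 2 (0.08 log units; that floor lies within the scatter). Compound 3 `COc1ccc(N2C(=O)COc3ccc(-c4cnc5ccccc5c4)cc32)cc1` carries a different core; how the two cores differ is not broken down here. In this assay compound 3 also reaches only a limit of the assay, > 40000 nM. Compound 4 `O=C1COc2ccc(-c3cnc4ccccc4c3)cc2N1c1ccc(F)cc1`, not yet measured, differs from compound 3 by fluoro in place of methoxy on an aromatic carbon, the same change as from compound 1 to compound 2, at a place described in identical words. The whole picture rests on (the limit of > 40000 nM in this assay, at which 2 of the 3 values shown sit). For compound 4 the expected step is a step that the limit leaves unreadable from compound 3 to compound 4, resting on the earlier step of an at least 1.2-fold higher number from compound 1 to compound 2 (0.08 log units; that floor lies within the scatter). Compound 4 is therefore expected to give 60000 nM, between 40000 nM and 120000 nM, most probably reported only as a limit.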

Compound 4, half-maximal inhibitory concentration: > 40000 nM
Compound 4: no number, only a limit (the forecaster's own chance of this, stated with the estimate: 90%); the middle value does not contradict the limit.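

Compound 3 and compound 4 both reach only a limit in this assay, not a number, so no step can be read between them: the limit of > 40000 nM in this assay, at which 3 of the 4 values shown sit.

The compounds shown leave open whether fluoro in place of methoxy changes anything on the core of compound 3, and whether that core can give a numerical value in this assay at all.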